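The source may hold more compounds than are shown below. What is called first, only, known or untested is meant among the compounds shown, and "the series" means these compounds.

Measured so far:
Compound 1, `CCCCCCC(O)[C@H](CC(C)C)NC(=O)[C@@H](NC(=O)[C@@H](NC(=O)OC(C)(C)C)C(C)C)C(C)C`: 210 nM
Compound 2, `CCCCCCC(O)[C@H](CC(C)C)NC(=O)[C@@H](NC(=O)[C@@H](NC(=O)CC(C)C)C(C)C)C(C)C`: 920 nM

In an assay on isolated protein (plant) for inhibition of Pepsin A (Sus scrofa) (on this read-out lower numbers stand for stronger inhibition and higher numbers for weaker inhibition), compound 2 stands at the higher of the two numbers obtained. Going by the values given here, its only neighbour is compound 1, and the step between them, a 4.4-fold higher number from compound 1 to compound 2 (0.64 log units; beyond the scatter), is the single measured step in this set; it concerns the group on the carbonyl carbon of the terminal acyl group.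

Compound 3, `CCCCCCC(O)[C@H](CC(C)C)NC(=O)[C@@H](NC(=O)[C@@H](NC(=O)CC(C)(C)C)C(C)C)C(C)C`, continues along the same acyl group. It differs from compound 2 by methyl in place of hydrogen on a saturated chain carbon bound to three saturated chain carbons, which, read one bond further out, is isobutyl to neopentyl, or isobutylcarbonyl to neopentylcarbonyl. Among the compounds with values here, no measured step covers the addition of a methyl at this place; the step from compound 1 to compound 2 exchanged the whole group rather than enlarging it, so it bears on the new change only in showing that this position is not indifferent. With nothing more to go on, compound 3 is expected to remain close to compound 2, a step of a 1.5-fold lower number from compound 2 to compound 3 (0.19 log units; within the scatter) that stays within the scatter. The estimate for compound 3 in this assay is therefore 600 nM, with a range from 200 nM to 2000 nM.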

Compound 3, half-maximal inhibitory concentration: 1100 nM
Compound 3: the middle estimate sits 1.8-fold (0.26 log units) below what was measured, within the range that was stated.
By their numbers in this assay, from the lowest: compound 1; then compounds 2 and 3 (each within the scatter of the next).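

In this assay, adding a methyl on a saturated chain carbon bound to three saturated chain carbons, which turns isobutyl into neopentyl, gives a step that lies within the scatter: a 1.2-fold higher number from compound 2 to compound 3 (0.08 log units; within the scatter). Compound 3 carries the same tert-butyl end as the tert-butoxy of compound 1, yet the step between them remains beyond the scatter, a 5.2-fold higher number from compound 1 to compound 3 (0.72 log units; beyond the scatter), so that end alone does not bring the number back to that of compound 1, and the two carbon-linked groups of compound 2 and compound 3 read alike against it. Nothing available explains this result.

On these data alone, whether other oxygen-linked groups on this carbonyl carbon, such as methoxy or benzyloxy, would read like tert-butoxy remains open, as does the effect of a longer chain or a phenyl group in the same place. The rest of the core is the same in all three compounds, so whether the gap between tert-butoxy and the carbon-linked groups holds on a different core also stays unanswered.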